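Notes on the series: from compound 3 to compound 4

A few compounds are considered here, and "the series" means these few. Any claim that something is new, unique, unknown or untested is made for them only; others in the source may bear on it.

Measured in a functional assay on HepG2 cells (Homo sapiens) for antiproliferative activity, read by MTT assay, with a stated time of 48 h; on this read-out lower numbers stand for stronger inhibition and higher numbers for weaker inhibition:
compound 1, `O=C(/C=C/c1ccc(/C=C/C(=O)c2cc(Cl)ccc2Cl)o1)NO`, gives 48300 nM
compound 2, `O=C(/C=C/c1ccc(/C=C/C(=O)c2ccc3ccccc3c2)o1)NO`, gives 9930 nM
compound 3, `O=C(/C=C/c1ccc(/C=C/C(=O)c2ccc(Cl)cc2)o1)NO`, gives 6740 nM

Compound 3 has the lowest number of the three; compound 2 sits within the scatter of it, while compound 1 lies well beyond. Compound 4, `Cc1ccc(C(=O)/C=C/c2ccc(/C=C/C(=O)NO)o2)cc1`, is not yet measured in this assay. It differs from compound 3 in one place: methyl in place of chloro on an aromatic carbon. Going by the values given here, no step between measured compounds shows the same change, so the expectation rests only on the small size of the change. For compound 4 the step of a 1.3-fold higher number from compound 3 to compound 4 (0.13 log units; within the scatter) is expected to stay within the scatter, with no clear direction. The estimate for compound 4 in this assay is 9000 nM, between 3500 nM and 25000 nM.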

Compound 4, half-maximal inhibitory concentration: 16000 nM
The estimate for compound 4 lay 1.8-fold (0.25 log units) below the measured number, within the range that was stated.
By their numbers in this assay, from the lowest: compounds 3, 2 and 4 (each within the scatter of the next, the first and the last beyond it); then compound 1.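

In this assay, going by these compounds alone, the change from 4-chlorophenyl to 4-methylphenyl gives the first step between compounds differing in one place: a 2.4-fold higher number from compound 3 to compound 4 (0.38 log units; beyond the scatter). This aromatic carbon therefore responds to the exchange of one heavy atom for another, although the count of hydrogen-bond donors and acceptors and the net charge stay the same. Nothing measured here accounts for the step.

Open, going by these compounds, is how an amine, a methoxy group or a carboxylic acid on this carbon would read. Also open, on these data alone, is whether methyl in place of chloro gives a similar step elsewhere on the ring.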